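A few compounds are considered here, and "the series" means these few. Any claim that something is new, unique, unknown or untested is made for them only; others in the source may bear on it.

Of the compounds shown here, three built on a shared core have been measured so far in an in vitro ADME assay on microsomes from liver (Homo sapiens) for metabolic stability; on this read-out higher numbers stand for fast clearance and lower numbers for slow clearance. Compound 1 (`O=C(COCc1ccccc1)N1CCN(c2ccc(F)cc2F)CC1`) gives 580 mL.min-1.g-1 as the highest number of the three. Compound 2 (`O=C(COCc1ccncc1)N1CCN(c2ccc(Cl)cc2)CC1`) gives 17 mL.min-1.g-1 as the lowest. Compound 3 (`O=C(COCc1cccnc1)N1CCN(c2ccc(Cl)cc2Cl)CC1`) stands between them with 210 mL.min-1.g-1 as its number, lower than compound 1 and higher than compound 2, and both gaps lie beyond the usual scatter of repeated measurements. These three compounds differ from one another in more than one place, so their gaps cannot be tied to any single group.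

Compound 4 (`O=C(COCc1cncs1)N1CCN(c2ccc(Cl)cc2Cl)CC1`) has not been measured yet. It differs from compound 3 in one group only (1,3-thiazol-5-yl in place of pyridin-3-yl on a saturated chain carbon bound to an oxygen on a saturated carbon), with 1,3-thiazol-5-yl in place of pyridin-3-yl on a saturated chain carbon bound to an oxygen on a saturated carbon. One aromatic ring replaces another, and the rest of the molecule stays the same. Among the measured compounds shown here, no measured pair shows what a swap of this kind does, so the best available guide is compound 3 with its 210 mL.min-1.g-1 as the starting point. The expected step (a 1.1-fold higher number from compound 3 to compound 4 (0.04 log units; within the scatter)) is not expected to go beyond the scatter, in either direction. For compound 4 the estimated clearance is 230 mL.min-1.g-1 with an expected range from 90 mL.min-1.g-1 to 550 mL.min-1.g-1 on this measurement.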

Compound 4, intrinsic clearance in microsomes: 73 mL.min-1.g-1
Compound 4: middle estimate off by 3.2-fold (0.50 log units), on the high side; the whole stated range lies above it.
By their numbers in this assay, from the lowest: compound 2; then compound 4; then compound 3; then compound 1.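

In this assay, swapping pyridin-3-yl for 1,3-thiazol-5-yl on a saturated chain carbon bound to an oxygen on a saturated carbon gives a 2.9-fold lower number from compound 3 to compound 4 (0.46 log units; beyond the scatter), the first gap in this set that can be tied to a single group. It shows that the aromatic ring at this position is not a silent part of the molecule: with everything else held the same, changing this ring alone moves the read-out towards slow clearance. The swap changes several things at once, from a six-membered aromatic ring with 1 hetero atom to a five-membered one with 2 hetero atoms, one of them sulfur, and nothing available here says which of these differences matters.

This single pair cannot show whether the swap would give a similar step on a compound with the rest of the molecule as in compound 1 or compound 2. Nor can it show how other rings at this position would behave: a 1,3-oxazol-5-yl group, with oxygen in place of the sulfur, or a pyridin-3-yl ring carrying an added amine, would each test a different part of the change.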